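The source may report more compounds than this note shows. Statements on the series, on what has been measured and on what is new or still open speak of the compounds shown alone.

In a functional assay on MCF7 cells (Homo sapiens) for antiproliferative activity, read by WST assay, with a stated time of 5 days (on this read-out higher numbers stand for weaker inhibition and lower numbers for stronger inhibition), compound 1 (`COc1cc(O)c2c(c1O)C[C@]1(C)O[C@@H]1CC[C@@]1(C)O[C@@H]1C2=O`) gives 17000 nM and compound 2 (`COc1cc(O)c2c(c1O)C/C(C)=C\CC[C@@]1(C)O[C@@H]1C2=O`) gives 15000 nM. These two numbers lie within the usual scatter, so compound 2 cannot be told apart from compound 1 in this assay. Compound 3 (`COc1cc(O)c2c(c1O)[C@@H](O)/C(C)=C\CC[C@@]1(C)O[C@@H]1C2=O`) differs from compound 2 in one place: hydroxy in place of hydrogen on a saturated ring carbon. Going by the values given here, no measured pair shows what such a change does, so no shift beyond the scatter is expected, and the estimate is a 1.1-fold lower number from compound 2 to compound 3 (0.03 log units; within the scatter). For compound 3 the expected value is 14000 nM, with an estimated range from 5000 nM to 40000 nM.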

Compound 3, half-maximal inhibitory concentration: 6200 nM
Estimate against measurement, compound 3: 2.3-fold (0.35 log units) above; the measured number falls inside the stated range.
By their numbers in this assay, from the lowest: compound 3; then compounds 2 and 1 (each within the scatter of the next).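

In this assay, placing hydroxy in place of hydrogen on this saturated ring carbon, next to the ring atom that bears a methyl group, gives a 2.4-fold lower number from compound 2 to compound 3 (0.38 log units; beyond the scatter), a modest change. Going by these compounds alone, the earlier compounds offered no readable step, so this is the first sign that this position of the ring can affect the read-out. No evidence is available to explain the shift. Going by these compounds, whether the opposite arrangement of the hydroxy at this carbon would behave alike remains open. So does the effect of an amine or a methoxy group here.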